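Working Notes: Cell Toxicity of Two Measured Compounds

A few compounds are considered here, and "the series" means these few. Any claim that something is new, unique, unknown or untested is made for them only; others in the source may bear on it.

Measured so far:
compound 1 `CCCOCN1c2ccccc2C(=O)NS1(=O)=O` gives > 50 ug/mL
compound 2 `CC(=O)OCCOCN1c2ccccc2C(=O)N(Cc2ccccc2)S1(=O)=O` gives 100 ug/mL

In a functional assay on HEL cells (Homo sapiens) (on this read-out higher numbers stand for lower toxicity in this test and lower numbers for higher toxicity in this test), compound 1 sits only at a limit, not a number: the limit of > 50 ug/mL in this assay, at which 1 of the 2 values shown sits. In this assay compound 2 gives 100 ug/mL. Compound 3 `O=C1NS(=O)(=O)N(COCc2ccccc2)c2ccccc21` is still to be measured; it differs from compound 1 by phenyl in place of ethyl on a saturated chain carbon bound to an oxygen on a saturated carbon. Going by the values given here, no step between measured compounds is available here, so no measured precedent sets the size. The step that the limit leaves unreadable from compound 1 to compound 3 is expected to stay within the scatter, or close to it. Compound 3 is expected to give about 60 ug/mL, with a range from 20 ug/mL to 150 ug/mL, and a fair chance of again returning only a limit.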

Compound 3, half-maximal cytotoxic concentration: > 50 ug/mL
Compound 3 was reported as a limit; the forecaster's own chance of this, stated with the estimate: 50%; the middle value lies beyond the limit too.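

No step can be read from compound 1 to compound 3, since both are reported only as limits: the limit of > 50 ug/mL in this assay, at which 2 of the 3 values shown sit.

Going by these compounds, whether phenyl in place of ethyl shifts the half-maximal cytotoxic concentration at all remains open.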